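Amine swap on the side chain, carried to a second core

This account rests on a few compounds, and the source may have more. Where it says the series, first, only, none or still open, it means among the compounds named here.

Measured compounds:
compound 1 `CCNCC(=O)Nc1cc(OC)ccc1C(=O)c1ccc(OC)c2c1OC(C)(C)C=C2`, 3690 nM
compound 2 `COc1ccc(C(=O)c2ccc(OC)c3c2OC(C)(C)C=C3)c(NC(=O)CN(C)C)c1`, 1590 nM
compound 3 `C=C(c1ccc2c(c1)C=CC(C)(C)O2)c1ccc(OC)cc1NC(=O)CNCC`, 2220 nM

In a functional assay on HCT-8 cells (Homo sapiens) for antiproliferative activity, read by MTT assay, with a stated time of 48 h (a higher number here means a weaker inhibitor, a lower number a stronger inhibitor), compound 1 gives 3690 nM and compound 2 gives 1590 nM. The two share a core and differ only in the side chain: dimethylamino in place of ethylamino on a saturated chain carbon bound to a carbonyl carbon. That change produced a 2.3-fold lower number from compound 1 to compound 2 (0.37 log units; beyond the scatter).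

Compound 3 is built on a different core; the difference between the cores of compound 1 and compound 3 is not broken down here. In this assay compound 3 gives 2220 nM, a number within the scatter of both compound 1 and compound 2, so no order among the three can be read from it.

Compound 4 `C=C(c1ccc2c(c1)C=CC(C)(C)O2)c1ccc(OC)cc1NC(=O)CN(C)C` has not yet been measured. It stands to compound 3 as compound 2 stands to compound 1: dimethylamino in place of ethylamino on a saturated chain carbon bound to a carbonyl carbon. The place of the change is the same in both pairs, so the same change is being repeated on a second core.

Going by the values given here, the only guide to the size of the step is the one measured pair, where the change gave a 2.3-fold lower number from compound 1 to compound 2 (0.37 log units; beyond the scatter). For compound 4 a step of similar size is expected, a 2.0-fold lower number from compound 3 to compound 4 (0.30 log units; within the scatter), because compound 3 sits at 2220 nM and the change is identical. The different core makes the carry-over uncertain, so the range is kept wide. Compound 4 is estimated at 1100 nM, between 500 nM and 2500 nM.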

Compound 4, half-maximal inhibitory concentration: 690 nM
Compound 4: middle estimate off by 1.6-fold (0.20 log units), on the high side, and the stated range covers the measured number.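

In this assay, the second core repeats the result of the first: dimethylamino in place of ethylamino on a saturated chain carbon bound to a carbonyl carbon gives a 3.2-fold lower number from compound 3 to compound 4 (0.51 log units; beyond the scatter). The change therefore carries over between these two cores in direction, and the two steps cannot be told apart in size: the same change on two cores in this assay, a 2.3-fold lower number (0.37 log units; beyond the scatter) from compound 1 to compound 2 and a 3.2-fold lower number (0.51 log units; beyond the scatter) from compound 3 to compound 4, 1.4-fold (0.14 log units) apart, within the scatter of two such steps This rests on two matched pairs only, so it does not show that the step would hold on any further core, does not explain why the number falls, and gives no measure of what the difference between the cores itself contributes.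

Open for the series is how far the side-chain trend extends beyond ethylamino and dimethylamino, for instance to diethylamino, to an unsubstituted amino group, or to a longer chain between the amide and the amine. Also open, on these data alone, is whether the same step would appear on either core in a cell line other than HCT-8 or at an exposure time other than the one used here.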